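The source may hold more compounds than are shown below. What is called first, only, known or untested is meant among the compounds shown, and "the series" means these compounds.

Measured so far in a functional assay on the whole organism with Mus musculus as the target; a higher number here means that more compound is needed for the effect, a lower number that less compound is needed:

- compound 1 `CNC(=O)Cn1c(-c2ccc(Cl)cc2)nc2cccnc21` gives 12.5 mg/kg
- compound 2 `CCCN(C)C(=O)Cn1c(-c2ccc(Cl)cc2)nc2cccnc21` gives 11.6 mg/kg
- compound 3 `O=C(Cn1c(-c2ccc(Cl)cc2)nc2cccnc21)N1CCCC1` gives 17.9 mg/kg

Compound 3 is not separated from the other two: a 1.4-fold higher number from compound 1 to compound 3 (0.16 log units; within the scatter) and a 1.5-fold higher number from compound 2 to compound 3 (0.19 log units; within the scatter) both stay within the scatter. The next change leads to compound 4 `O=C(Cn1c(-c2ccc(Cl)cc2)nc2cccnc21)Nc1ccccn1` and is (pyridin-2-yl)amino in place of pyrrolidin-1-yl on a carbonyl carbon. The two steps above are the ones made on that same carbonyl carbon, and a 1.1-fold lower number from compound 1 to compound 2 (0.03 log units; within the scatter) adds a third small step nearby. Among the measured compounds shown here, none of the measured compounds carries an aromatic ring at this place, so the new group lies outside what the data cover. On the small size of those steps, no shift beyond the scatter is expected, in either direction. The expected step is a 1.3-fold lower number from compound 3 to compound 4 (0.11 log units; within the scatter) as an estimate with little weight on its direction. For compound 4 the estimated value is 14 mg/kg, with an expected range from 5 mg/kg to 40 mg/kg, kept wide for the untested aromatic ring.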

Compound 4, dose for half-maximal effect: 100 mg/kg
The estimate for compound 4 lay 7.1-fold (0.85 log units) below the measured number; the whole stated range lies below it.
By their numbers in this assay, from the lowest: compounds 2, 1 and 3 (each within the scatter of the next); then compound 4.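

In this assay, the place on a carbonyl carbon showed no step beyond the scatter among methylamino, methyl(propyl)amino and pyrrolidin-1-yl, but it does respond to (pyridin-2-yl)amino, with more compound needed (a 5.6-fold higher number from compound 3 to compound 4 (0.75 log units; beyond the scatter); an 8.6-fold higher number from compound 2 to compound 4 (0.94 log units; beyond the scatter)). The amide hydrogen is present in both compound 1 and compound 4, so the rise seen with pyridin-2-yl in place of methyl on the amide-type nitrogen (an 8.0-fold higher number from compound 1 to compound 4 (0.90 log units; beyond the scatter)) cannot be tied to the presence of that hydrogen alone. No measurement at hand explains the rise.

Going by these compounds, it remains open whether the rise goes with the aromatic ring itself or with its ring nitrogen, which phenylamino would help to separate. Benzylamino and a methyl on the nitrogen of the (pyridin-2-yl)amino group are further open cases.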